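This account rests on a few compounds, and the source may have more. Where it says the series, first, only, none or still open, it means among the compounds named here.

Compound 1 `N#CC1=C(N)Oc2c(N)cc3nc4ccccc4nc3c2C12C(=O)N(Cc1cnnn1-c1cccc(C(F)(F)F)c1)c1ccccc12` gives 31600 nM in a functional assay on MCF7 cells (Homo sapiens) for antiproliferative activity, read by MTT assay, with a stated time of 48 h; a higher number here means a weaker inhibitor, a lower number a stronger inhibitor.
Compound 2 `N#CC1=C(N)Oc2c(N)cc3nc4ccccc4nc3c2C12C(=O)N(Cc1cnnn1-c1ccc(Cl)cc1Cl)c1ccccc12` reaches only a limit of this assay, > 50000 nM.
Compound 3 `COc1ccc(OC)c(-n2nncc2CN2C(=O)C3(C(C#N)=C(N)Oc4c(N)cc5nc6ccccc6nc5c43)c3ccccc32)c1` gives 28100 nM in this assay.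

Of the two numbers in hand, compound 3 has the lowest, with compound 1 nearest a 1.1-fold lower number from compound 1 to compound 3 (0.05 log units; within the scatter); compound 2 sits at a limit (the limit of > 50000 nM in this assay, at which 1 of the 3 values shown sits). Compound 4 `N#CC1=C(N)Oc2c(N)cc3nc4ccccc4nc3c2C12C(=O)N(Cc1cnnn1-c1ccc([N+](=O)[O-])cc1[N+](=O)[O-])c1ccccc12` differs from compound 3 in one place: 2,4-dinitrophenyl in place of 2,5-dimethoxyphenyl on an aromatic nitrogen. Within the data shown here, the steps that bear on this all exchange the aryl group on that aromatic nitrogen. The exchange an at least 1.5-fold higher number from compound 1 to compound 2 (0.19 log units; that floor lies within the scatter) and the exchange an at least 1.7-fold lower number from compound 2 to compound 3 (0.25 log units; that floor lies within the scatter) each end or start at the limit of compound 2, and the exchange from compound 1 to compound 3 stays within the scatter. None of these aryl exchanges produced a number clearly better than the others, and the closest shown analogue of a 2,4-dinitrophenyl, the 2,4-dichlorophenyl of compound 2, gave only a limit. Compound 4 is therefore expected to show a 1.5-fold higher number from compound 3 to compound 4 (0.17 log units; within the scatter) in this assay, with a real chance of a limit again. The estimate for compound 4 is 42000 nM, with a range from 18000 nM to 100000 nM.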

Compound 4, half-maximal inhibitory concentration: 20900 nM
Estimate against measurement, compound 4: 2.0-fold (0.30 log units) above, and the stated range covers the measured number.
By their numbers in this assay, from the lowest: compounds 4, 3 and 1 (each within the scatter of the next). At a limit, above all of these: compound 2.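

In this assay, among the aryl exchanges on the aromatic nitrogen, only the change from 2,4-dichlorophenyl to 2,4-dinitrophenyl gives a step beyond the scatter, an at least 2.3-fold lower number from compound 2 to compound 4 (0.37 log units; beyond the scatter). The 2,4-dinitrophenyl group is not set apart from the other two aryl groups, with a 1.3-fold lower number from compound 3 to compound 4 (0.13 log units; within the scatter) and a 1.5-fold lower number from compound 1 to compound 4 (0.18 log units; within the scatter), so these three aryl groups read alike at this position. Compound 2 alone remains at a limit: the limit of > 50000 nM in this assay, at which 1 of the 4 values shown sits.

From the compounds shown here alone, the true size of the step from the 2,4-dichlorophenyl group stays open, as only its floor can be read. Also open, going by these compounds, is whether a phenyl ring carrying an amine or a carboxylic acid, or a plain alkyl chain in place of the ring, would give a number clearly apart from these.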